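The compounds below may be only part of what the source reports. "The series", "measured", "known", "first", "only" and "open" are said of these compounds alone.

In an ADME assay on BJ cells (Homo sapiens) for cytotoxicity, read by CellTiter-Glo and resazurin assay, with a stated time of 72 h (a higher number here means that more compound is needed for the effect, a lower number that less compound is needed), two compounds of this series have been measured so far. Compound 1, `CC(C)N(Cc1cccc(OCCCCCC(=O)O)c1)C(=O)c1ccc(-c2cccc(Cl)c2)cc1`, gives > 21900 nM, which is a limit of the assay rather than a number. Compound 2, `CCOC(=O)CCCCCOc1cccc(CN(C(=O)c2ccc(-c3ccc4ccccc4c3)cc2)C(C)C)c1`, gives > 26000 nM in this assay, again a limit and not a number. Compound 2 therefore stands at a limit, (the limit of > 26000 nM in this assay, at which 1 of the 2 values shown sits). Among the compounds with values here, the only other value shown is also a limit, (the limit of > 21900 nM in this assay, at which 1 of the 2 values shown sits). Compound 3, `CCOC(=O)CCCCCOc1cccc(CN(C(=O)c2ccc(-c3ccc4cc[nH]c4c3)cc2)C(C)C)c1`, has not yet been measured. It differs from compound 2 in one place: 1H-indol-6-yl in place of naphthalen-2-yl on an aromatic carbon. Within the data shown here, no step between two measured compounds is available to show what such a change does in this assay. With both measured values sitting at limits, the step from compound 2 to compound 3 is expected to be none beyond the scatter, estimated as a step that the limit leaves unreadable from compound 2 to compound 3. Compound 3 is accordingly expected to give about 30000 nM in this assay, within a range from 10000 nM to 100000 nM, and most likely only as a limit once more.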

Compound 3, half-maximal effective concentration: > 26000 nM
Compound 3 was reported as a limit (the forecaster's own chance of this, stated with the estimate: 80%); the middle value lies beyond the limit too.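

Within the data shown here, compound 2 and compound 3 are both reported only as limits in this assay, and no step between them can be read. The compounds shown leave open whether 1H-indol-6-yl in place of naphthalen-2-yl changes the concentration needed for the effect at all.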